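Aminoalkyl chain against benzyl on the shared core

The compounds below may be only part of what the source reports. "The series", "measured", "known", "first", "only" and "open" are said of these compounds alone.

Compound 2 `O=C(NCc1ccc(F)cc1)c1nc(Br)c2cccnc2c1NCc1ccccc1` carries a benzylamino group on the shared core. In a functional assay on MCF7 cells (Homo sapiens) for cytotoxicity, read by MTT assay, with a stated time of 72 h (a higher number here means a weaker inhibitor, a lower number a stronger inhibitor), compound 2 has "not determined" (no result reported), so no single number places it on the scale. Among the compounds with values here, the only measured member of the series is compound 1 `NCCCNc1c(C(=O)NCc2ccc(F)cc2)nc(Br)c2cccnc12`, which in this assay gives 6000 nM. Compound 3 `NCCCCCCNc1c(C(=O)NCc2ccc(F)cc2)nc(Br)c2cccnc12` is the next entry for this assay. The change from compound 2 to compound 3 is 5-aminopentyl in place of phenyl on a saturated chain carbon bound to a nitrogen on an aromatic ring. Because compound 2 has no value, the step from compound 2 to compound 3 cannot be sized from data; what can be said rests on compound 1, which already carries an aminoalkyl chain of this kind and in this assay gives 6000 nM. Between compound 1 and compound 3 a step of no more than the usual scatter is expected, with no clear direction. Compound 3 is therefore estimated at 4500 nM, within a range from 1500 nM to 14000 nM.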

Compound 3, half-maximal inhibitory concentration: 2000 nM
The estimate for compound 3 lay 2.3-fold (0.35 log units) above the measured number, within the range that was stated.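

In this assay the change of 3-aminopropyl in place of amino on a saturated chain carbon, three bonds along the chain from a nitrogen on an aromatic ring, gives a 3.0-fold lower number from compound 1 to compound 3 (0.48 log units; beyond the scatter) and so shows that this position on the shared core responds to extending the aminoalkyl chain. This is a single step between two chains and does not establish a trend with chain length. No measurement shown accounts for the step.

The step from compound 2 to compound 3 cannot be read, so the benzyl and 6-aminohexyl groups remain uncompared at this position. A plain hexyl chain without the amine would separate the contribution of the amine from that of chain length, and an 8-aminooctyl chain would show whether the change continues with a longer chain.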